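Swapping the aryl group: from chlorophenyl to cyanofluorophenyl

The source may hold more compounds than are shown below. What is called first, only, known or untested is meant among the compounds shown, and "the series" means these compounds.

Compound 1 `CC/C(=C(/c1ccc(/C=C/C(=O)O)cc1)c1cc2ccccc2[nH]1)c1ccccc1Cl` gives 42 nM in a functional assay on MCF7 cells (Homo sapiens) for inhibition; on this read-out higher numbers stand for weaker inhibition and lower numbers for stronger inhibition.
Compound 2 `CC/C(=C(/c1ccc(/C=C/C(=O)O)cc1)c1cc2ccccc2[nH]1)c1cccc(C(F)(F)F)c1` gives 325 nM in this assay.
Compound 3 `CC/C(=C(/c1ccc(/C=C/C(=O)O)cc1)c1cc2ccccc2[nH]1)c1ccc(Cl)cc1` gives 343 nM in this assay.

Compound 3 has the highest number of the three, though its value and that of compound 2 lie within the scatter of each other; compound 1 sits well below both. The change now considered leads to compound 4 `CC/C(=C(/c1ccc(/C=C/C(=O)O)cc1)c1cc2ccccc2[nH]1)c1cccc(F)c1C#N`: 2-cyano-3-fluorophenyl in place of 4-chlorophenyl on a double-bonded chain carbon bound to a double-bonded chain carbon and a saturated chain carbon.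

Going by the values given here, no measured step matches this change exactly. The closest is an 8.2-fold higher number from compound 1 to compound 3 (0.91 log units; beyond the scatter), which shows that moving from a 2-chlorophenyl to a 4-chlorophenyl raises the number considerably; a 7.7-fold higher number from compound 1 to compound 2 (0.89 log units; beyond the scatter) points the same way for a 3-(trifluoromethyl)phenyl. Compound 4 returns to a ring substituted as in the 2-chlorophenyl of compound 1, but with a nitrile and a fluorine rather than a chlorine, so the recovery is uncertain. A lowering step is therefore expected, a 3.1-fold lower number from compound 3 to compound 4 (0.49 log units; beyond the scatter), landing between compound 1 and compound 3. The expected value for compound 4 is 110 nM, with a range from 30 nM to 400 nM.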

Compound 4, half-maximal inhibitory concentration: 40 nM
Estimate against measurement, compound 4: 2.8-fold (0.44 log units) above, within the range that was stated.
By their numbers in this assay, from the lowest: compounds 4 and 1 (each within the scatter of the next); then compounds 2 and 3 (each within the scatter of the next).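

In this assay, placing the 2-cyano-3-fluorophenyl group on the double-bonded chain carbon gives an 8.6-fold lower number from compound 3 to compound 4 (0.93 log units; beyond the scatter) and, against the 3-(trifluoromethyl)phenyl group, an 8.1-fold lower number from compound 2 to compound 4 (0.91 log units; beyond the scatter). Against the 2-chlorophenyl group the same swap gives a 1.1-fold lower number from compound 1 to compound 4 (0.02 log units; within the scatter), so chlorine is not needed for a low number at this place: a ring carrying a nitrile and a fluorine does as well. Among these four compounds, the two low numbers belong to groups with a substituent numbered 2, and neither compound 2 nor compound 3 has one.

Going by these compounds, whether a 2-cyanophenyl group without the fluorine, or a 2-aminophenyl group, would keep the number low remains open. No evidence is at hand that bears on what lies behind these differences.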